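Chloro to cyano at the assay limit

A few compounds are considered here, and "the series" means these few. Any claim that something is new, unique, unknown or untested is made for them only; others in the source may bear on it.

Compound 1 `COC(=O)c1cccc(-c2ccc(-n3cccc3)nn2)c1`: > 25000 nM (a limit)
Compound 2 `CCN(CC)c1ccc(-c2cccc(Cl)c2)nn1`: > 25000 nM (a limit)

In an ADME assay on cells (Fibroblast, Homo sapiens) for antiproliferative activity, with a stated time of 48 h (a lower number here means a stronger inhibitor, a higher number a weaker inhibitor), compound 2 gives > 25000 nM, which is a limit and not a number. Among the measured compounds shown here, the series so far holds only (the limit of > 25000 nM in this assay, at which 2 of the 2 values shown sit). Compound 3 `CCN(CC)c1ccc(-c2cccc(C#N)c2)nn1` has cyano in place of chloro on an aromatic carbon, meta to a large group: cyano in place of chloro on an aromatic carbon. For the measured compounds named here, with compound 2 at the limit > 25000 nM and no measured step to size the change, no step beyond the scatter is expected in either direction. The estimated change is a step that the limit leaves unreadable from compound 2 to compound 3. For compound 3 the expected value is 30000 nM, with an estimated range of 15000 nM to 60000 nM.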

Compound 3, half-maximal inhibitory concentration: > 25000 nM
Compound 3 was reported as a limit (the forecaster's own chance of this, stated with the estimate: 80%); the middle value lies beyond the limit too.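

No step from chloro to cyano can be read between compound 2 and compound 3 in this assay, since both values are limits: the limit of > 25000 nM in this assay, at which 3 of the 3 values shown sit.

The compounds shown leave open whether any change on the shared core gives a readable value.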